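The compounds below may be only part of what the source reports. "The series", "measured", "known", "first", "only" and "open" are said of these compounds alone.

Working notes on the series

Three compounds of this series carry values in an assay on membranes from brain for displacement of a labelled ligand from Sigma non-opioid intracellular receptor 1 (Cavia porcellus); on this read-out higher numbers stand for weaker inhibition and lower numbers for stronger inhibition. Compound 1 `C=CC(=O)O[C@@H](Cc1ccccc1)CN1CCN(CCCN(c2ccc(F)cc2)c2ccc(F)cc2)CC1` gives 45.5 nM. Compound 2 `C=CC(=O)OC(CCN1CCN(CCCN(c2ccc(F)cc2)c2ccc(F)cc2)CC1)c1ccccc1` gives 87.3 nM, and compound 3 `CC(=O)OC(CCN1CCN(CCCN(c2ccc(F)cc2)c2ccc(F)cc2)CC1)c1ccccc1` gives 56.6 nM. Compound 1 sits at the low end of the three numbers, but neither its gap to compound 3 nor its gap to compound 2 reaches beyond the scatter. For the measured compounds named here, the only single-point step among the measured compounds is a 1.5-fold lower number from compound 2 to compound 3 (0.19 log units; within the scatter), which swaps one acyl group for another while the ester stays in place.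

Compound 4 `O[C@@H](Cc1ccccc1)CN1CCN(CCCN(c2ccc(F)cc2)c2ccc(F)cc2)CC1` differs from compound 1 by hydrogen in place of vinylcarbonyl on an oxygen on a saturated carbon. Going by the values given here, no measured step removes the ester altogether, so the step from compound 2 to compound 3 bears on it only loosely; that step was within the scatter. Among the compounds with values here, with no direct precedent, the expected step of a 1.2-fold higher number from compound 1 to compound 4 (0.08 log units; within the scatter) is taken as small, in no firm direction. Compound 4 is estimated at 55 nM, with a range from 15 nM to 200 nM.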

Compound 4, inhibition constant: 28.1 nM
The estimate for compound 4 lay 2.0-fold (0.29 log units) above the measured number; the range from low to high includes it.
By their numbers in this assay, from the lowest: compounds 4, 1, 3 and 2 (each within the scatter of the next, the first and the last beyond it).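

In this assay, the step from ester to free alcohol gives a 1.6-fold lower number from compound 1 to compound 4 (0.21 log units; within the scatter), so removing the whole vinylcarbonyl from this oxygen on a saturated carbon, rather than only exchanging one acyl group for another, stays within the scatter. The second step, a 2.0-fold lower number from compound 3 to compound 4 (0.30 log units; within the scatter), also stays within the scatter, but it changes the chain carrying the oxygen as well as the acyl group and so says less about this position alone. Nothing available explains either step.

The compounds shown leave open whether a methyl ether, an amine or a longer acyl chain at this position would also stay within the scatter of compound 4. They also leave open how the free hydroxy would read on the chain of compound 2.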